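Cytotoxicity of four amide analogues in human kidney cells

This account rests on a few compounds, and the source may have more. Where it says the series, first, only, none or still open, it means among the compounds named here.

Compound 1 `COc1cccc(-c2ccc(C(=O)N(Cc3cccc(OCCCCCC(=O)O)c3)C(C)C)cc2)c1`, compound 2 `Cc1nnc(-c2cccc(-c3ccc(C(=O)N(Cc4cccc(OCCCCCC(=O)O)c4)C(C)C)cc3)c2)o1` and compound 3 `CCOC(=O)CCCCCOc1cccc(CN(C(=O)c2ccc(-c3cccc(-c4nnc(C)o4)c3)cc2)C(C)C)c1` were tested in an ADME assay on HEK293 cells (Homo sapiens) for cytotoxicity, read by CellTiter-Glo and resazurin assay, with a stated time of 72 h; a higher number here means that more compound is needed for the effect, a lower number that less compound is needed. Compound 1 gives only a limit of the assay, > 20900 nM. Compound 2 also gives only a limit, > 26000 nM. Compound 3 likewise gives only a limit, > 26000 nM. Taken together, the data are the limit of > 20900 nM in this assay, at which 1 of the 3 values shown sits, and (the limit of > 26000 nM in this assay, at which 2 of the 3 values shown sit), so no compound can be placed above or below another.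

The core of compound 2 and the core of compound 3 differ in one counted place, (ethyl in place of hydrogen on an oxygen next to a carbonyl group), and the step that the two limits leave unreadable from compound 2 to compound 3 is hidden by the limits. Compound 1 arises from compound 2 by methoxy in place of 5-methyl-1,3,4-oxadiazol-2-yl on an aromatic carbon, and the step that the two limits leave unreadable from compound 2 to compound 1 is equally unreadable.

Compound 4 `CCOC(=O)CCCCCOc1cccc(CN(C(=O)c2ccc(-c3cccc(OC)c3)cc2)C(C)C)c1` awaits measurement in this assay. It arises from compound 3 by methoxy in place of 5-methyl-1,3,4-oxadiazol-2-yl on an aromatic carbon, the same change as from compound 2 to compound 1, made on the other core. Because compound 3 sits at a limit, > 26000 nM, the step that the limit leaves unreadable from compound 3 to compound 4 is expected to be small and itself unreadable. Compound 4 is therefore expected to give 30000 nM, most likely again as a limit.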

Compound 4, half-maximal effective concentration: > 21000 nM
Compound 4 was reported as a limit; the forecaster's own chance of this, stated with the estimate: 85%; the middle value does not contradict the limit.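

In this assay, compound 4 gives only a limit, > 21000 nM. Compound 1 and compound 3 also give only limits, so neither step to compound 4, from compound 1 or from compound 3, can be read. The compounds shown leave open at what concentration any of the four becomes cytotoxic, and whether either structural change alters that concentration.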